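A few compounds are considered here, and "the series" means these few. Any claim that something is new, unique, unknown or untested is made for them only; others in the source may bear on it.

Measured in an ADME assay on HFF cells (Homo sapiens) for cytotoxicity, with a stated time of 8 days; a lower number here means that less compound is tolerated, a higher number that more compound is tolerated:
- compound 1 `Nc1nc(NCc2ccccc2)c2ncn(/C=C3/CC3(CO)CO)c2n1`: > 300000 nM (a limit)
- compound 2 `Nc1nc(N2CCCC2)c2ncn(/C=C3/CC3(CO)CO)c2n1`: > 300000 nM (a limit)

Compound 2 stands only at a limit, > 300000 nM. Compound 3 `CCCNc1nc(N)nc2c1ncn2/C=C1/CC1(CO)CO` carries propylamino in place of pyrrolidin-1-yl on an aromatic carbon. Among the measured compounds shown here, the one measured step bearing on this is a step that the two limits leave unreadable from compound 1 to compound 2, also with a change at that aromatic carbon, and it gives no size. For the measured compounds named here, the series so far rests on (the limit of > 300000 nM in this assay, at which 2 of the 2 values shown sit). In this assay the expected step is a number no higher from compound 2 to compound 3 (the limit leaves the size open), with none expected beyond the scatter. Compound 3 is estimated at 300000 nM, with an expected range from 100000 nM to 500000 nM.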

Compound 3, half-maximal cytotoxic concentration: > 300000 nM
Compound 3 gave a limit, no number (the forecaster's own chance of this, stated with the estimate: 85%); the middle value sits exactly at the limit.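

In this assay compound 1, compound 2 and compound 3 each stand only at a limit, so no step among them can be read: the limit of > 300000 nM in this assay, at which 3 of the 3 values shown sit.

The compounds shown leave open at what concentration any of them turns cytotoxic, and whether the groups on the aromatic carbon differ in this.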